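The source may hold more compounds than are shown below. What is called first, only, known or untested is meant among the compounds shown, and "the series" means these compounds.

Measured compounds:
compound 1, `N=C(N)N/N=C/c1ccc(/C=C/C(=O)c2ccc(Br)cc2)cc1`, in a functional assay on the whole organism (Ear) for inhibition, with Mus musculus as the target, with a stated time of 30 min, at a dose of 100 mg/kg by the intraperitoneal route; a lower number here means less inhibition, a higher number more inhibition at the dose given (going by the name of the read-out): 68.9%
compound 2, `Cc1ccc(C(=O)/C=C/c2ccc(/C=N/NC(=N)N)cc2)c(C)c1`: 64.2%

Among the measured compounds shown here, compound 2 stands lowest of the two numbers, but the only measured step, a number 4.7 percentage points lower from compound 1 to compound 2 (within the scatter), lies within the scatter, so the two compounds cannot be told apart on these data. Compound 3, `N=C(N)N/N=C/c1ccc(/C=C/C(=O)c2ccc(Cl)cc2Cl)cc1`, carries 2,4-dichlorophenyl in place of 2,4-dimethylphenyl on a carbonyl carbon. That single step bears on the change, since it too swaps the ring on the carbonyl carbon, and it stayed within the scatter; the expected step is a number 1.8 percentage points higher from compound 2 to compound 3 (within the scatter), nothing beyond the scatter in either direction. Compound 3 is estimated at 66%, with a range from 50% to 82%.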

Compound 3, a percentage reported as inhibition, in the whole organism at one dose (the size of the read-out at that dose, not a potency): 92.5%
Estimate against measurement, compound 3: 26.5 percentage points below; the whole stated range lies below it.
By their numbers in this assay, from the lowest: compounds 2 and 1 (each within the scatter of the next); then compound 3.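

In this assay, the ring on the carbonyl carbon clearly moves the read-out: 2,4-dichlorophenyl in place of 2,4-dimethylphenyl gives a number 28.3 percentage points higher from compound 2 to compound 3 (beyond the scatter) and in place of 4-bromophenyl gives a number 23.6 percentage points higher from compound 1 to compound 3 (beyond the scatter) at the same dose. Among the compounds shown here, the earlier pair showed no such separation, so this is the first sign that the choice of ring at this place counts. Nothing available explains the rise. As far as these compounds go, it remains open whether the rise needs both chlorines, and how a ring carrying an amine or a carboxylic acid instead would compare.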